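This account rests on a few compounds, and the source may have more. Where it says the series, first, only, none or still open, it means among the compounds named here.

Going by the values given here, in a toxicity assay on HEK-293T cells (Homo sapiens) for cytotoxicity, read by MTT assay, with a stated time of 72 h (a lower number here means a stronger inhibitor, a higher number a weaker inhibitor), compound 1 `O=C1c2c[n+]([O-])c3ccccc3c2C(=O)c2c1c1ccccc1n2Cc1cn([C@@H]2C[C@H](O)[C@@H](CO)O2)nn1` gives 820 nM, the highest of the three numbers so far, with compound 2 `CC1(C)O[C@@H](CO)[C@H](Cn2cc(Cn3c4c(c5ccccc53)C(=O)c3c[n+]([O-])c5ccccc5c3C4=O)nn2)O1` at 120 nM and compound 3 `CN1CCN(CCCn2c3c(c4ccccc42)C(=O)c2c[n+]([O-])c4ccccc4c2C3=O)CC1` at 170 nM. Compound 4 `O=C1c2c[n+]([O-])c3ccccc3c2C(=O)c2c1c1ccccc1n2Cc1cn([C@H]2C[C@H](O)[C@@H](CO)O2)nn1` keeps every atom and bond of compound 1: the two compounds have the same atoms and bonds and differ only in configuration as drawn: 1 of 3 stereo elements differ; a stereocentre at a saturated ring carbon is drawn S in compound 1 and R in compound 4. Among the compounds with values here, no measured step changes configuration alone. The nearest guide is a 6.8-fold lower number from compound 1 to compound 2 (0.83 log units; beyond the scatter), but there the whole group on the aromatic nitrogen is replaced, so it only sets an outer size. A single stereocentre is a smaller edit, so in this assay little or no change beyond the scatter is expected, with a slight lean towards a lower number. The expected step is a 1.4-fold lower number from compound 1 to compound 4 (0.14 log units; within the scatter). For compound 4 the estimated value is 600 nM, within an expected range of 220 nM to 1600 nM.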

Compound 4, half-maximal inhibitory concentration: 3600 nM
The estimate for compound 4 lay 6.0-fold (0.78 log units) below the measured number, outside the stated range (above it).
By their numbers in this assay, from the lowest: compounds 2 and 3 (each within the scatter of the next); then compound 1; then compound 4.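

A single stereocentre at a saturated ring carbon is enough to shift the number in this assay, with a 4.4-fold higher number from compound 1 to compound 4 (0.64 log units; beyond the scatter), and that shift can be assigned to this centre alone because of one fact: the fact that compounds 1 and 4 differ only in the configuration as drawn. So the group on the aromatic nitrogen matters through its drawn configuration as well as through its atoms, and the gap between the two groups widens to a 30-fold higher number from compound 2 to compound 4 (1.48 log units; beyond the scatter).

On these data alone, whether the remaining stereo elements matter as much stays open. So does whether a plain amine on the aromatic nitrogen would show any such difference.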